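One Group Swap Carried Over to a Second Core

This account rests on a few compounds, and the source may have more. Where it says the series, first, only, none or still open, it means among the compounds named here.

Three compounds have been measured in a functional assay on HL-60 cells (Homo sapiens) for inhibition, read by trypan blue exclusion, with a stated time of 72 h; on this read-out higher numbers stand for weaker inhibition of growth and lower numbers for stronger inhibition of growth:
compound 1 `C=C(C)C(=O)c1ccc(OCc2nc(-c3ccc([N+](=O)[O-])cc3)cs2)c(C)c1C` gives 5100 nM;
compound 2 `C=C(C)C(=O)c1ccc(OCc2nc(-c3ccc4ccccc4c3)cs2)c(C)c1C` gives 2300 nM;
compound 3 `C=C(CC)C(=O)c1ccc(OCc2nc(-c3ccc([N+](=O)[O-])cc3)cs2)cc1Cl` gives 800 nM.

Compound 1 and compound 2 share a core and differ in one place only, (naphthalen-2-yl in place of 4-nitrophenyl on an aromatic carbon). In this assay this change gave a 2.2-fold lower number from compound 1 to compound 2 (0.35 log units; beyond the scatter). Compound 4 `C=C(CC)C(=O)c1ccc(OCc2nc(-c3ccc4ccccc4c3)cs2)cc1Cl` has not been measured yet. It differs from compound 3 by the same change, (naphthalen-2-yl in place of 4-nitrophenyl on an aromatic carbon), at the same place. How the core of compound 3 differs from the core of compound 1 is not broken down here; among the measured compounds, compound 3 shows the lowest number. For compound 4 a step of similar size is expected in this assay, a 2.0-fold lower number from compound 3 to compound 4 (0.30 log units; within the scatter), because the same change once gave a 2.2-fold lower number from compound 1 to compound 2 (0.35 log units; beyond the scatter). Compound 4 is therefore estimated at 400 nM, with a likely range from 150 nM to 1000 nM.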

Compound 4, concentration for 50% growth inhibition: 900 nM
Compound 4: the middle estimate sits 2.3-fold (0.35 log units) below what was measured, and the stated range covers the measured number.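

In this assay, the step of a 1.1-fold higher number from compound 3 to compound 4 (0.05 log units; within the scatter) shows that replacing 4-nitrophenyl with naphthalen-2-yl on this second core gave no change that can be told from scatter. Among the compounds shown here, this does not prove that the swap acts identically on both cores, since only two matched pairs are available, but neither do they show that the core alters its effect. The two steps cannot be separated on these data:
the same change on two cores in this assay, a 2.2-fold lower number (0.35 log units; beyond the scatter) from compound 1 to compound 2 and a 1.1-fold higher number (0.05 log units; within the scatter) from compound 3 to compound 4, 2.5-fold (0.40 log units) apart, within the scatter of two such steps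

The compounds shown leave open how a group carrying a carboxylic acid or an amine would compare in place of 4-nitrophenyl. They also leave open whether the swap behaves the same way on any further core.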